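A few compounds are considered here, and "the series" means these few. Any claim that something is new, unique, unknown or untested is made for them only; others in the source may bear on it.

Measured in an ADME assay on a cell-free system (plasma, Homo sapiens) for protein binding: compound 1 `Nc1nccc(N2CC[C@H](NC(=O)Nc3ccc(Cl)c(C(F)(F)F)c3)C2)n1` gives 99.5%. Compound 2 `CNc1nccc(N2CC[C@H](NC(=O)Nc3ccc(CN(C)C)c(C(F)(F)F)c3)C2)n1` gives 94.3%. Compound 3 `CNc1nccc(N2CC[C@H](NC(=O)Nc3ccc(CN4CCN(C)CC4)c(C(F)(F)F)c3)C2)n1` gives 87.6%.

Compound 3 stands with the highest unbound fraction of the three; compound 2 is nearest and compound 1 furthest, both steps to it beyond the scatter. Compound 4 `CNc1nccc(N2CC[C@H](NC(=O)Nc3ccc(CN4CCCC4)c(C(F)(F)F)c3)C2)n1` differs from compound 3 by pyrrolidin-1-yl in place of 4-methylpiperazin-1-yl on a saturated chain carbon bound to an aromatic carbon. Going by the values given here, the one measured step that bears on this is a 2.2-fold higher unbound fraction from compound 2 to compound 3 (0.34 log units; beyond the scatter), in which the second ring nitrogen entered. Compound 4 carries again a single nitrogen in the entering group, as compound 2 does in its dimethylamino group, so the binding of compound 4 is expected to move back toward compound 2, an estimated a 1.9-fold lower unbound fraction from compound 3 to compound 4 (0.28 log units; within the scatter). Compound 4 is estimated at 93.5%, with a range from 88.5% to 97%.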

Compound 4, plasma protein binding: 86.5%
Compound 4: middle estimate off by 2.1-fold (0.32 log units) (unbound fraction), on the low side; the whole stated range lies above it.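

In this assay, pyrrolidin-1-yl in place of 4-methylpiperazin-1-yl gives a 1.1-fold higher unbound fraction from compound 3 to compound 4 (0.04 log units; within the scatter), so the two groups are not separated at this position despite their different nitrogen counts. Pyrrolidin-1-yl in place of dimethylamino gives a 2.4-fold higher unbound fraction from compound 2 to compound 4 (0.37 log units; beyond the scatter), which puts both ring groups on the same side of the dimethylamino group in this small set. Nothing shown explains this result.

Still open, as far as these compounds go, is whether morpholin-4-yl or piperidin-1-yl at this place would read like these two ring groups. From the compounds shown here alone, the reading for a carboxylic acid on the same carbon is also open.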